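The source may report more compounds than this note shows. Statements on the series, on what has been measured and on what is new or still open speak of the compounds shown alone.

Compound 1 `COc1ccc2nc(-c3ccc(C)c(N)c3)sc2c1` — > 50000 nM
Compound 2 `COc1ccc2nc(-c3ccc(NC(=O)NCc4ccccc4)cc3)sc2c1` — > 50000 nM

Both measured compounds share one core and differ only in the group attached to it. They were tested in a functional assay on A549 cells (Homo sapiens) for cytotoxicity, read by MTT assay, with a stated time of 2 days; a higher number here means a weaker inhibitor, a lower number a stronger inhibitor. For compound 1 the result is not a number but a limit of the assay, > 50000 nM. For compound 2 the result is likewise a limit of the assay, > 50000 nM. So compound 2 stands at the edge of what this assay can report: no inhibition was found up to the top of the tested range, and the same holds for the other value shown (the limit of > 50000 nM in this assay, at which 2 of the 2 values shown sit). Nothing can be said about an order between compound 1 and compound 2.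

The next compound, compound 3 `COc1ccc2nc(-c3ccc(NC(=O)C4CC4)cc3)sc2c1`, keeps the amide-type nitrogen on the aromatic ring and changes only what sits on the carbonyl: cyclopropyl in place of benzylamino on a carbonyl carbon.

Within the data shown here, no step between measured compounds is available, so the size of this change in this assay cannot be read from the data. With both known values at the limit, the expectation is no movement beyond the scatter, and the expected step is a step that the limit leaves unreadable from compound 2 to compound 3. Compound 3 is therefore expected to give about 60000 nM, within a range of 20000 nM to 200000 nM, most likely again as a limit rather than a number.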

Compound 3, half-maximal inhibitory concentration: > 50000 nM
Compound 3 ended at the assay's limit; the forecaster's own chance of this, stated with the estimate: 80%; the middle value is on the limit's open side.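

Compound 3 gives > 50000 nM in this assay, which is a limit of the assay. Compound 2 also sits at a limit, so no step can be read from compound 2 to compound 3. The compounds shown leave open whether any of them differ in strength, and what a measurable value would look like, as all share one limit: the limit of > 50000 nM in this assay, at which 3 of the 3 values shown sit.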